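Lengthening the Alkyl Chain on an Inactive Benzyl-Protected Sugar

A few compounds are considered here, and "the series" means these few. Any claim that something is new, unique, unknown or untested is made for them only; others in the source may bear on it.

The shared core carries three benzyl ethers and a free hydroxyl; compound 1 `CC[C@H]1O[C@H](COCc2ccccc2)[C@@H](OCc2ccccc2)[C@H](OCc2ccccc2)[C@H]1O` bears an ethyl group on the ring. In a functional assay on HL-60 cells (Homo sapiens) for antiproliferative activity, read by MTT assay (on this read-out higher numbers stand for weaker inhibition and lower numbers for stronger inhibition), compound 1 gives "not active" (no number reported), so no single number marks where it stands. Its epimer compound 2 `CC[C@@H]1O[C@H](COCc2ccccc2)[C@@H](OCc2ccccc2)[C@H](OCc2ccccc2)[C@H]1O` differs only in configuration, (the fact that compounds 1 and 2 differ only in the configuration as drawn), and in this assay compound 2 gives 8200 nM, a weak result in itself. Compound 3 `CC(C)C[C@H]1O[C@H](COCc2ccccc2)[C@@H](OCc2ccccc2)[C@H](OCc2ccccc2)[C@H]1O` keeps the configuration of compound 1 and replaces (isopropyl in place of methyl on a saturated chain carbon bound to a saturated ring carbon). Among the measured compounds shown here, since compound 1 shows no measurable inhibition, there is no measured step from which to scale this change; the author expects at most a small shift, if any, in this assay, with an inactive outcome remaining the most likely. Compound 3 is therefore estimated at 20000 nM, within a range of 5000 nM to 80000 nM, and a result reported only as a limit is considered quite probable.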

Compound 3, half-maximal inhibitory concentration: 13900 nM
The estimate for compound 3 lay 1.4-fold (0.16 log units) above the measured number; measured number inside the range.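

In this assay, among the compounds shown here, compound 1 gives "not active" (no number reported), so no step to compound 3, at 13900 nM, can be read. With its ethyl group, compound 2 gives 8200 nM; the compounds shown leave open how an isobutyl chain would fare in that configuration.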